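Swapping the Aryl Group on Compound 2

This account rests on a few compounds, and the source may have more. Where it says the series, first, only, none or still open, it means among the compounds named here.

Of the compounds shown here, three sharing one core have been tested in a functional assay on HeLa S3 cells (Homo sapiens) for antiproliferative activity, read by XTT assay, with a stated time of 72 h; a higher number here means a weaker inhibitor, a lower number a stronger inhibitor. Compound 1 `COc1ncnc2c1c(-c1ccsc1)cn2[C@@H]1O[C@H](CO)[C@@H](O)[C@H]1O` gives 3350 nM in this assay. Compound 2 `CN(C)c1ncnc2c1c(-c1ccsc1)cn2[C@@H]1O[C@H](CO)[C@@H](O)[C@H]1O`, which carries dimethylamino in place of methoxy on an aromatic carbon, reaches only a limit of the assay, > 15000 nM. Compound 3 `CNc1ncnc2c1c(-c1ccsc1)cn2[C@@H]1O[C@H](CO)[C@@H](O)[C@H]1O` likewise reaches only a limit, > 20000 nM. The change from compound 1 to compound 2 is an at least 4.4-fold higher number from compound 1 to compound 2 (0.65 log units; beyond the scatter), from compound 1 to compound 3 an at least 5.9-fold higher number from compound 1 to compound 3 (0.77 log units; beyond the scatter), and from compound 2 to compound 3 a step that the two limits leave unreadable from compound 2 to compound 3. Compound 2 thus stands at a limit of this assay, with no exact number known for it.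

Compound 4 `CN(C)c1ncnc2c1c(-c1cc3ccccc3o1)cn2[C@@H]1O[C@H](CO)[C@@H](O)[C@H]1O` differs from compound 2 in one place: 1-benzofuran-2-yl in place of thiophen-3-yl on an aromatic carbon. Within the data shown here, none of the measured steps touches this part of the molecule; all three vary the group on the other aromatic carbon, so no measured step bears directly on this change, and the size of the step can only be guessed. Compound 4 is therefore expected to lie close to compound 2, with a step of an at least 1.2-fold lower number from compound 2 to compound 4 (0.09 log units; that floor lies within the scatter), and its estimated value in this assay is 12000 nM, with a range from 2500 nM to 50000 nM.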

Compound 4, half-maximal inhibitory concentration: > 20000 nM
Compound 4 was reported as a limit (the forecaster's own chance of this, stated with the estimate: 50%); middle value at least 1.6-fold (0.22 log units) away from the limit.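

In this assay compound 4 gives only a limit, > 20000 nM. Among these compounds, compound 2 also stands at a limit, so no step between compound 2 and compound 4 can be read. Going by these compounds, whether 1-benzofuran-2-yl in place of thiophen-3-yl changes activity at all remains open.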